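The compounds below may be only part of what the source reports. "The series", "measured", "known", "first", "only" and "open" are said of these compounds alone.

Measured compounds:
Compound 2, `O=C(CCCCCNC(=O)c1cc(-c2ccc(F)cc2)[nH]n1)NO`: 47600 nM
Compound 1, `CCCc1cc(-c2ccc(F)cc2)nn1Cc1ccc(C(=O)NO)cc1`: 16800 nM

Of these two numbers, compound 2 has the highest; compound 1 lies at a lower number, and that gap is beyond the scatter. Compound 3 `O=C(CCCCNC(=O)c1cc(-c2ccc(F)cc2)[nH]n1)NO` differs from compound 2 by hydroxycarbamoyl in place of (hydroxycarbamoyl)methyl on a saturated chain carbon, four bonds along the chain from an amide-type nitrogen. Within the data shown here, no measured pair shows a step of this kind, so the expectation rests on the change alone: in a functional assay on HepG2 cells (Homo sapiens) for antiproliferative activity, read by MTT assay, with a stated time of 96 h (on this read-out lower numbers stand for stronger inhibition of growth and higher numbers for weaker inhibition of growth), only a small shift toward a higher number is expected, a 1.3-fold higher number from compound 2 to compound 3 (0.10 log units; within the scatter). Compound 3 is estimated at 60000 nM, with a likely range from 20000 nM to 180000 nM.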

Compound 3, concentration for 50% growth inhibition: > 100000 nM
Compound 3 ended at the assay's limit; the forecaster's own chance of this, stated with the estimate: 20%; middle value at least 1.6-fold (0.22 log units) away from the limit.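

Replacing (hydroxycarbamoyl)methyl with hydroxycarbamoyl on a saturated chain carbon, four bonds along the chain from an amide-type nitrogen, gives an at least 2.1-fold higher number from compound 2 to compound 3 (0.32 log units; beyond the scatter). This shows that the shorter chain at this position weakens inhibition of growth rather than leaving it unchanged. In this assay compound 3 gives > 100000 nM as a limit of the assay and not a number: the limit of > 100000 nM in this assay, at which 1 of the 3 values shown sits.

As far as these compounds go, the full size of the step therefore stays unknown. From the compounds shown here alone, whether a longer chain carrying hydroxycarbamoyl would give a lower number, and what a carboxylic acid in place of hydroxycarbamoyl would do, also remains open.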